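The source may report more compounds than this note shows. Statements on the series, on what has been measured and on what is new or still open speak of the compounds shown alone.

Measured in a functional assay on KB-V1 cells (Homo sapiens) for cytotoxicity, read by MTT assay, with a stated time of 72 h; a lower number here means a stronger inhibitor, a higher number a weaker inhibitor:
- compound 1 `CC(C)NC(=S)N/N=C1\C(=O)Nc2ccccc21`: 10300 nM
- compound 2 `CNC(=S)N/N=C1\C(=O)Nc2ccccc21`: 19400 nM
- compound 3 `O=C1Nc2ccccc2/C1=N/NC(=S)Nc1ccc(Cl)cc1`: 4990 nM

Compound 3 has the lowest number of the three at 4990 nM, and its steps to both of the others lie beyond the scatter. That makes it the strongest inhibitor measured so far, though only modestly so.

Compound 4 `O=C1Nc2ccccc2/C1=N/NC(=S)Nc1ccc(C(F)(F)F)cc1` has trifluoromethyl in place of chloro on an aromatic carbon, para to a large group (trifluoromethyl in place of chloro on an aromatic carbon). For the measured compounds named here, no measured compound carries trifluoromethyl, so no step shows this exchange directly. The nearest evidence comes from changes of the group on the amide-type nitrogen. Bringing in 4-chlorophenyl gave a 2.1-fold lower number from compound 1 to compound 3 (0.31 log units; beyond the scatter) and a 3.9-fold lower number from compound 2 to compound 3 (0.59 log units; beyond the scatter), while methyl in place of isopropyl gave a 1.9-fold higher number from compound 1 to compound 2 (0.27 log units; within the scatter). Even these exchanges of a whole group moved the number only modestly. The change in compound 4 is confined to one substituent on the 4-chlorophenyl group, so no step beyond the scatter is expected in this assay.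

The estimated step is a 1.1-fold lower number from compound 3 to compound 4 (0.04 log units; within the scatter). For compound 4 the expected value is 4500 nM, with an estimated range of 1800 nM to 11000 nM.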

Compound 4, half-maximal inhibitory concentration: 2100 nM
Estimate against measurement, compound 4: 2.1-fold (0.33 log units) above, within the range that was stated.
By their numbers in this assay, from the lowest: compound 4; then compound 3; then compounds 1 and 2 (each within the scatter of the next).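

The change from chloro to trifluoromethyl, on an aromatic carbon para to a large group, gives a 2.4-fold lower number from compound 3 to compound 4 (0.38 log units; beyond the scatter) in this assay. The earlier steps shown here all exchanged the whole group on the amide-type nitrogen, and they left open whether a single substituent on the 4-chlorophenyl group could matter; this step shows that it can, moving the number beyond the scatter by a modest amount, so this position is not indifferent to what it carries. Nothing measured here accounts for the lower number, and the reason for the step remains unknown.

For the compounds shown here, this position is represented by only two groups, chloro and trifluoromethyl, and one step between them cannot establish a trend, so it is unclear how a smaller group such as fluoro, or a different kind of group such as methoxy, an amine or a carboxylic acid, would behave there. From the compounds shown here alone, it is also open whether trifluoromethyl would give a similar step at another place on the same ring, or with the core of compound 4 altered elsewhere.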